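The compounds below may be only part of what the source reports. "The series", "measured", "known", "first", "only" and "open" are said of these compounds alone.

Compound 1 `O=S(=O)(Nc1ccc(Oc2cnc3ccccc3c2)c(Cl)c1)c1ccc(Cl)cc1Cl` gives 50400 ng.h/mL
Compound 2 `N#Cc1cc(NS(=O)(=O)c2ccc(Cl)cc2Cl)ccc1Oc1cncc(Cl)c1` gives 14100 ng.h/mL
Compound 3 `O=S(=O)(Nc1cc(Cl)c(Oc2cnc3ccccc3c2)c(Cl)c1)c1ccc(C(F)(F)F)cc1Cl` gives 61400 ng.h/mL

These three numbers come from an ADME assay on the whole organism (plasma, strain Sprague-Dawley) for pharmacokinetics, with Rattus norvegicus as the target, with a stated time of 24 h, at a dose of 5 mg/kg by the oral route; a higher number here means more compound in the circulation at the dose given, a lower number less compound in the circulation. Compound 1 sits at the upper end of the set, within the scatter of compound 3, while compound 2 lies lower, beyond the scatter from compound 1.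

The next compound to be tested is compound 4 `CC(=O)c1cc(NS(=O)(=O)c2ccc(Cl)cc2Cl)ccc1Oc1cnc2ccccc2c1`, which keeps the core of compound 1 but has acetyl in place of chloro on an aromatic carbon. Within the data shown here, no two measured compounds differ in one place alone, so the size of this step has no direct precedent, and the remaining evidence is indirect. Compound 1 and compound 3 both carry chloro on that aromatic carbon. Compound 2 carries a nitrile there and reaches 14100 ng.h/mL, although it also differs elsewhere, so it offers only a weak hint.

On that hint, a drop is expected in this assay rather than a rise. The expected change is a 2.1-fold lower number from compound 1 to compound 4 (0.32 log units; beyond the scatter), a step near the edge of the scatter. For compound 4 the estimated value is 24000 ng.h/mL, with an expected range from 8000 ng.h/mL to 60000 ng.h/mL.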

Compound 4, area under the concentration-time curve: 1660 ng.h/mL
Compound 4: the middle estimate sits 14-fold (1.16 log units) above what was measured; the whole stated range lies above it.
By their numbers in this assay, from the lowest: compound 4; then compound 2; then compounds 1 and 3 (each within the scatter of the next).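

Among these compounds, this is the first step in this assay that changes one place alone, and it shows that the aromatic carbon ortho to a large group and meta to a large group is far from a silent position: acetyl in place of chloro gives a 30-fold lower number from compound 1 to compound 4 (1.48 log units; beyond the scatter), a large step and well beyond the scatter. The change is confined to one substituent, with three heavy atoms entering for one, along with a double bond outside aromatic rings and a hydrogen-bond acceptor, while no ring, hydrogen-bond donor or net charge is added, so even a swap this limited can move the number strongly. Nothing in the data shown accounts for the size of this fall.

The compounds shown leave open whether the fall belongs to acetyl in particular or would also follow from other groups on this carbon, such as methyl, methoxy or an amine. They also leave open whether the same swap would produce a step of similar size on compound 3, which carries chloro on this carbon too.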